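The source may hold more compounds than are shown below. What is called first, only, known or untested is meant among the compounds shown, and "the series" means these compounds.

Of the compounds shown here, two from this series have been measured. Compound 1, with the structure `CCCc1ncc(-c2nc(C(F)(F)F)sc2N2CCN(C(=O)Cn3cnc4cccnc43)[C@H](C)C2)cn1`, and compound 2, with the structure `CCOc1ncc(-c2nc(C(F)(F)F)sc2N2CCN(C(=O)Cn3ccc4cccnc43)[C@H](C)C2)cn1`, share the same core and differ in the group attached to the acetyl carbon and in the substituent on the six-membered ring at the far end. In a functional assay on U2OS cells for antagonist activity at C-X-C chemokine receptor type 3 (Homo sapiens), read by beta-arrestin recruitment (a higher number here means a weaker inhibitor, a lower number a stronger inhibitor), compound 1 gives 33 nM. In this assay, within the data shown here, compound 2 gives 47 nM, which is the highest of the two numbers so far, though its gap to compound 1 lies within the scatter of repeated measurements, so the two compounds cannot be told apart on these data.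

Compound 3, with the structure `CCOc1ncc(-c2nc(C(F)(F)F)sc2N2CCN(C(=O)Cn3cnc(C(F)(F)F)n3)[C@H](C)C2)cn1`, is the next compound in line. It differs from compound 2 in one place: a group of 9 heavy atoms (3 carbon, 3 nitrogen, 3 fluorine; one five-membered aromatic ring with 3 hetero atoms) in place of a group of 9 heavy atoms (7 carbon, 2 nitrogen; one five-membered aromatic ring with 1 hetero atom, one six-membered aromatic ring with 1 hetero atom), on a saturated chain carbon bound to a carbonyl carbon. No comparable exchange has been measured within this set, so the direction of the effect cannot be read from a precedent. Compound 3 is expected to be somewhat weaker than compound 2, with a step of a 2.1-fold higher number from compound 2 to compound 3 (0.33 log units; beyond the scatter), and its value in this assay is estimated at 100 nM, within a range from 30 nM to 400 nM.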

Compound 3, half-maximal inhibitory concentration: 118 nM
For compound 3 the middle estimate is 1.2-fold (0.07 log units) below the measured one, and the stated range covers the measured number.
By their numbers in this assay, from the lowest: compounds 1 and 2 (each within the scatter of the next); then compound 3.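

Among these compounds, this is the first step that changes one place only, the group on a saturated chain carbon bound to a carbonyl carbon, so its effect in this assay can be read on its own: the exchange gives a 2.5-fold higher number from compound 2 to compound 3 (0.40 log units; beyond the scatter), a modest step beyond the scatter. The count of 9 heavy atoms stays the same, but a group with one five-membered and one six-membered aromatic ring gives way to 3-(trifluoromethyl)-1H-1,2,4-triazol-1-yl, which has a single five-membered aromatic ring, and compound 3 still gives a measurable number of 118 nM in this assay. No measurement at hand bears on what lies behind this step.

The pair changes the ring count and adds the trifluoromethyl group at once, so it remains open which of the two accounts for the step, and a 1,2,4-triazole with a methyl group or with only hydrogen in place of trifluoromethyl would separate them. Also open, on these data alone, is how this position responds to quite different groups, such as an amine or a carboxylic acid.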